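Amide nitrogen substitution in a pyridyl-vinyl diaryl ether series

A few compounds are considered here, and "the series" means these few. Any claim that something is new, unique, unknown or untested is made for them only; others in the source may bear on it.

Measured so far:
compound 1 `COc1ccc(NC(=O)c2cc(Oc3ccc(/C=C/c4ccccn4)cc3)ccn2)cc1` — 30000 nM
compound 2 `CNC(=O)c1cc(Oc2ccc(/C=C/c3ccncc3)cc2)ccn1` — 18200 nM

Two compounds have numbers in a functional assay on HepG2 cells (Homo sapiens) for antiproliferative activity, read by CCK-8 assay, with a stated time of 48 h; on this read-out lower numbers stand for stronger inhibition and higher numbers for weaker inhibition. Compound 1 `COc1ccc(NC(=O)c2cc(Oc3ccc(/C=C/c4ccccn4)cc3)ccn2)cc1` gives 30000 nM in this assay, and compound 2 `CNC(=O)c1cc(Oc2ccc(/C=C/c3ccncc3)cc2)ccn1` gives 18200 nM. Compound 2 holds the lower of the two numbers, but its gap to compound 1 lies within the scatter, so no order between the two is claimed.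

Compound 3 `COc1ccc(NC(=O)c2cc(Oc3ccc(/C=C/c4ccncc4)cc3)ccn2)cc1` differs from compound 2 by 4-methoxyphenyl in place of methyl on an amide-type nitrogen. Within the data shown here, no measured pair shows this change on its own, so any expectation rests on the two numbers alone. Compound 1 already carries a 4-methoxyphenyl on its amide nitrogen and gives 30000 nM, a number within the scatter of compound 2 at 18200 nM; on that basis no step beyond the scatter is expected in this assay, and the estimated step reads a 1.2-fold higher number from compound 2 to compound 3 (0.08 log units; within the scatter). Compound 3 is therefore estimated at 22000 nM, with a range of 8000 nM to 60000 nM.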

Compound 3, half-maximal inhibitory concentration: > 100000 nM
Compound 3: no number, only a limit; the forecaster's own chance of this, stated with the estimate: 10%; middle value at least 4.5-fold (0.65 log units) from the limit.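

In this assay compound 3 stands at a limit of the assay and not at a number: the limit of > 100000 nM in this assay, at which 1 of the 3 values shown sits. With pyridin-4-yl held, 4-methoxyphenyl in place of methyl on the amide-type nitrogen gives an at least 5.4-fold higher number from compound 2 to compound 3 (0.73 log units; beyond the scatter) and so shows that this nitrogen's substituent counts in this assay, which compounds 1 and 2 could not show, as they differ in two places. With 4-methoxyphenyl held, pyridin-4-yl in place of pyridin-2-yl gives an at least 3.3-fold higher number from compound 1 to compound 3 (0.52 log units; beyond the scatter) as a second single change, so the ring on the double-bonded chain carbon counts as well.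

From the compounds shown here alone, both steps are lower bounds, so their true sizes remain open. Also open, going by these compounds, is how the number runs with ethyl, unsubstituted phenyl or a plain hydrogen on the amide-type nitrogen, and with pyridin-3-yl on the chain.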